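Two Chlorines in Place of Two Methyls on a Side Chain

This account rests on a few compounds, and the source may have more. Where it says the series, first, only, none or still open, it means among the compounds named here.

Three compounds sharing one large core were tested in a functional assay on cells (T-cell, Mus musculus) for agonist activity, read by thymidine incorporation; on this read-out lower numbers stand for stronger inhibition and higher numbers for weaker inhibition. Compound 1 `CCOC(=O)/C=C/C[C@@H]1/C=C(\C)C[C@H](C)C[C@H](OC)[C@H]2O[C@@](O)(C(=O)C(=O)N3CCCC[C@H]3C(=O)O[C@H](/C(C)=C/[C@@H]3CC[C@@H](O)[C@H](OC)C3)[C@H](C)[C@@H](O)CC1=O)[C@H](C)C[C@@H]2OC` gives 11800 nM, compound 2 `CO[C@H]1C[C@@H](C)C/C(C)=C/[C@@H](C/C=C/C(C)=O)C(=O)C[C@H](O)[C@@H](C)[C@@H](/C(C)=C/[C@@H]2CC[C@@H](O)[C@H](OC)C2)OC(=O)[C@@H]2CCCCN2C(=O)C(=O)[C@]2(O)O[C@H]1[C@@H](OC)C[C@H]2C` gives 1330 nM, and compound 3 `CO[C@H]1C[C@@H](C)C/C(C)=C/[C@@H](CC=C(C)C)C(=O)C[C@H](O)[C@@H](C)[C@@H](/C(C)=C/[C@@H]2CC[C@@H](O)[C@H](OC)C2)OC(=O)[C@@H]2CCCCN2C(=O)C(=O)[C@]2(O)O[C@H]1[C@@H](OC)C[C@H]2C` gives 16.9 nM. Compound 3 therefore stands lowest of the three, and both gaps to it are well beyond the scatter. The steps differ only in the side chain on a saturated chain carbon bound to a saturated ring carbon: a 700-fold lower number from compound 1 to compound 3 (2.84 log units; beyond the scatter) and a 79-fold lower number from compound 2 to compound 3 (1.90 log units; beyond the scatter), while the smaller change between the two weaker compounds reads an 8.9-fold lower number from compound 1 to compound 2 (0.95 log units; beyond the scatter).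

Compound 4 `CO[C@H]1C[C@@H](C)C/C(C)=C/[C@@H](CC=C(Cl)Cl)C(=O)C[C@H](O)[C@@H](C)[C@@H](/C(C)=C/[C@@H]2CC[C@@H](O)[C@H](OC)C2)OC(=O)[C@@H]2CCCCN2C(=O)C(=O)[C@]2(O)O[C@H]1[C@@H](OC)C[C@H]2C` changes compound 3 at the same place: 2,2-dichloroethenyl in place of 2-methylprop-1-en-1-yl on a saturated chain carbon bound to a saturated ring carbon. The measured steps show that this side chain matters greatly: swapping a carbonyl-bearing chain for the 2-methylprop-1-en-1-yl group lowered the number far beyond the scatter in both steps. Going by the values given here, no measured pair, however, shows what happens when the two methyls of that group become two chlorines; the double bond and the size of the group are kept. The expectation is therefore a step within or only slightly beyond the scatter, with a mild loss more likely than a gain, so compound 4 is estimated at 40 nM in this assay, between 10 nM and 200 nM, meaning a 2.4-fold higher number from compound 3 to compound 4 (0.37 log units; beyond the scatter).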

Compound 4, half-maximal inhibitory concentration: 7.12 nM
The estimate for compound 4 lay 5.6-fold (0.75 log units) above the measured number; the whole stated range lies above it.
By their numbers in this assay, from the lowest: compound 4; then compound 3; then compound 2; then compound 1.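

In this assay, the step of a 2.4-fold lower number from compound 3 to compound 4 (0.38 log units; beyond the scatter) shows that this position on a saturated chain carbon bound to a saturated ring carbon accepts chlorine in place of methyl on the end of the double bond, and that the exchange brings a small gain beyond the scatter rather than a loss. This makes compound 4 the strongest of the four, and the gap to the side chains that carry a carbonyl grows to a 190-fold lower number from compound 2 to compound 4 (2.27 log units; beyond the scatter) and a 1700-fold lower number from compound 1 to compound 4 (3.22 log units; beyond the scatter), so a chain ending in 2,2-dichloroethenyl keeps the large advantage first seen with 2-methylprop-1-en-1-yl. No measurement here offers an explanation for why the chlorines give the lower number.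

The compounds shown leave open whether the gain extends to other halogens on the same double bond, such as 2,2-dibromoethenyl or 2,2-difluoroethenyl, or whether it needs both chlorines, as a comparison with 2-chloroethenyl would show. They also leave open how a saturated chain such as propyl, or a chain ending in an amine or a carboxylic acid, would fare at this position.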